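This account rests on a few compounds, and the source may have more. Where it says the series, first, only, none or still open, it means among the compounds named here.

Compound 1 `Clc1ccccc1OCC1=NCCO1` gives 30% in a toxicity assay on the whole organism with Rattus norvegicus as the target, at a dose of 200 mg/kg by the oral route; on this read-out higher numbers stand for a stronger effect at the one dose given and lower numbers for a weaker effect. Compound 2 `O=[N+]([O-])c1ccccc1OCC1=NCCO1` gives 25% in this assay.

Going by the values given here, the one measured step between these two, a number 5 percentage points lower from compound 1 to compound 2 (within the scatter), lies within the scatter of the assay. On the numbers shown, compound 2 stands at the lower of the two values, with compound 1 as its nearest neighbour at a distance that is within the scatter, so the two are not separated on this read-out. Compound 3 `Fc1ccccc1OCC1=NCCO1` differs from compound 2 by fluoro in place of nitro on an aromatic carbon. The step that bears on this change is the earlier exchange at the same aromatic carbon, a number 5 percentage points lower from compound 1 to compound 2 (within the scatter), which did not move the read-out beyond the scatter. A step of similar size is therefore expected here, with no shift beyond the scatter in either direction in this assay. The step of a number 2 percentage points higher from compound 2 to compound 3 (within the scatter) is expected to stay within the scatter. Compound 3 is thus estimated at 27%, in a range from 12% to 45%.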

Compound 3, a percentage reported as activity, at one dose (the size of the read-out at that dose, not a potency): 15%
Compound 3: middle estimate off by 12 percentage points, on the high side; low and high end bracket the measured number.
By their numbers in this assay, from the lowest: compounds 3, 2 and 1 (each within the scatter of the next, the first and the last beyond it).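

Going by these compounds alone, at this aromatic carbon the choice of group can now separate two compounds in this assay: fluoro in place of chloro gives a number 15 percentage points lower from compound 1 to compound 3 (beyond the scatter), the first step in this set to pass the scatter, though it is modest. Fluoro in place of nitro gives a number 10 percentage points lower from compound 2 to compound 3 (within the scatter), so compound 2 stays unseparated from both of the others, and only the chloro and fluoro pair has a firm order. Nothing offered here accounts for that modest step, which stands as an observation only.

The compounds shown leave open how an amine, a methoxy group or a plain hydrogen at this same carbon would read in this assay. They also leave open whether the exchange of chloro for fluoro would give a step of similar size at another aromatic carbon of the ring.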